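The source may hold more compounds than are shown below. What is called first, only, known or untested is meant among the compounds shown, and "the series" means these compounds.

Of the compounds shown here, three built on one shared core have been tested in a functional assay on A549 cells (Homo sapiens) for cytotoxicity, read by sulforhodamine B assay, with a stated time of 48 h, tested at 100 uM; a higher number here means a weaker effect of the compound at the concentration tested, a lower number a stronger effect. Compound 1 `COc1cc(-c2cc(/C=C/C(=O)c3ccc(N)cc3)[nH]n2)cc(OC)c1OC` gives -52%, compound 2 `COc1ccc(C(=O)/C=C/c2cc(-c3cc(OC)c(OC)c(OC)c3)n[nH]2)cc1OC` gives -78%, and compound 3 `COc1ccc(C(=O)/C=C/c2cc(-c3cc(OC)c(OC)c(OC)c3)n[nH]2)cc1` gives 1%. Compound 2 stands lowest of the three, with a number 26 percentage points lower from compound 1 to compound 2 (beyond the scatter) and a number 79 percentage points higher from compound 2 to compound 3 (beyond the scatter) both beyond the scatter. Compound 4 `COc1cc(C(=O)/C=C/c2cc(-c3cc(OC)c(OC)c(OC)c3)n[nH]2)cc(OC)c1OC` differs from compound 2 by methoxy in place of hydrogen on an aromatic carbon, the entering group sitting ortho to a methoxy group. The most relevant step is a number 79 percentage points higher from compound 2 to compound 3 (beyond the scatter), a large rise on removing a methoxy; adding one is the reverse kind of change, and the modest fall in a number 26 percentage points lower from compound 1 to compound 2 (beyond the scatter) points the same way. Compound 2 is already the lowest number here, so only a small step is expected, a number 8 percentage points higher from compound 2 to compound 4 (within the scatter). Compound 4 is expected to give -70%, between -95% and -20%.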

Compound 4, a percentage reported as activity, at one concentration (the size of the read-out at that concentration, not a potency): -66%
The estimate for compound 4 lay 4 percentage points below the measured number; the measured number falls inside the stated range.
By their numbers in this assay, from the lowest: compound 2; then compound 4; then compound 1; then compound 3.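

In this assay, methoxy in place of hydrogen, ortho to a methoxy group, gives a number 12 percentage points higher from compound 2 to compound 4 (beyond the scatter), so this addition does not lower the number further. The earlier loss of a methoxy gave a number 79 percentage points higher from compound 2 to compound 3 (beyond the scatter), and the two steps together show that more methoxy on this ring does not simply mean a stronger effect, although compound 4 at -66% remains strongly negative. No measured evidence accounts for this modest rise. Open, on these data alone, is how a hydroxyl, an ethoxy or a fluorine at this same place would compare with the methoxy of compound 4.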